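The source may report more compounds than this note shows. Statements on the series, on what has been measured and on what is new or still open speak of the compounds shown alone.

Working notes on the series. Compound 2 `CCCC(=O)N1CCC(NS(=O)(=O)c2ccc(NC(=O)c3ccc(CC)cc3)c3ccccc23)CC1` gives 10.8 nM in an in vitro functional assay on CHO/Galpha16 cells for antagonist activity at C-C chemokine receptor type 8 (Homo sapiens), read by FLIPR; a lower number here means a stronger inhibitor, a higher number a weaker inhibitor; compound 1 `CCCC(=O)N1CCC(NS(=O)(=O)c2ccc(NC(=O)c3ccc(C)cc3)c3ccccc23)CC1` gives 9.5 nM, and compound 3 `CCCC(=O)N1CCC(NS(=O)(=O)c2ccc(NC(=O)c3cc(C)oc3C(F)(F)F)c3ccccc23)CC1` gives 46.9 nM. Compound 2 thus stands second highest of the three; the nearest step to it is a 1.1-fold higher number from compound 1 to compound 2 (0.06 log units; within the scatter), and the furthest is a 4.3-fold higher number from compound 2 to compound 3 (0.64 log units; beyond the scatter). Compound 4 `CCCC(=O)N1CCC(NS(=O)(=O)c2ccc(NC(=O)c3cccnc3)c3ccccc23)CC1` carries pyridin-3-yl in place of 4-ethylphenyl on a carbonyl carbon. The steps that touch the same carbonyl carbon are a 4.9-fold higher number from compound 1 to compound 3 (0.69 log units; beyond the scatter) and a 4.3-fold higher number from compound 2 to compound 3 (0.64 log units; beyond the scatter), both modest losses on swapping the aryl ring. Within the data shown here, no step to a nitrogen-bearing six-membered ring is known, so a modest loss at most is expected, a 2.3-fold higher number from compound 2 to compound 4 (0.36 log units; beyond the scatter). Compound 4 is estimated at 25 nM, within 8 nM to 80 nM.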

Compound 4, half-maximal inhibitory concentration: 885 nM
For compound 4 the middle estimate is 35-fold (1.55 log units) below the measured one, outside the stated range (above it).
By their numbers in this assay, from the lowest: compounds 1 and 2 (each within the scatter of the next); then compound 3; then compound 4.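

On the carbonyl carbon, pyridin-3-yl brings the first large loss in the series (an 82-fold higher number from compound 2 to compound 4 (1.91 log units; beyond the scatter)) and (a 93-fold higher number from compound 1 to compound 4 (1.97 log units; beyond the scatter)), whereas the earlier ring swap cost only a modest step. It also falls well short of 5-methyl-2-(trifluoromethyl)furan-3-yl (a 19-fold higher number from compound 3 to compound 4 (1.28 log units; beyond the scatter)), so the aromatic rings at this position are far from interchangeable. Nothing measured here accounts for the loss.

The change both adds a ring nitrogen and removes the alkyl group, and these compounds cannot separate the two. An unsubstituted phenyl or a 6-methylpyridin-3-yl would divide them.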